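A few compounds are considered here, and "the series" means these few. Any claim that something is new, unique, unknown or untested is made for them only; others in the source may bear on it.

Compound 1 `COc1ccccc1/C=c1/[nH]c(=O)/c(=C\c2ccccc2OC)n(C)c1=O` carries two 2-methoxyphenyl groups on a shared core. Going by the values given here, in a functional assay on MCF7 cells (Homo sapiens) for cytotoxicity, read by CCK-8 assay, with a stated time of 72 h (a lower number here means a stronger inhibitor, a higher number a weaker inhibitor), compound 1 gives 9000 nM, the lowest of the two numbers measured so far. Among the compounds with values here, the only other measured compound is compound 2 `C=CCn1c(=O)/c(=C\c2ccccc2OC)[nH]c(=O)/c1=C\c1ccccc1OC`, which in this assay gives 41100 nM; the one measured step is a 4.6-fold higher number from compound 1 to compound 2 (0.66 log units; beyond the scatter), the change being a vinyl in place of hydrogen on a saturated chain carbon bound to an aromatic nitrogen.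

Compound 3 `COc1ccccc1/C=c1\c(=O)[nH]/c(=C/c2cccc(Cl)c2Cl)c(=O)n1C` has not been measured. It differs from compound 1 by 2,3-dichlorophenyl in place of 2-methoxyphenyl on a double-bonded chain carbon bound to an aromatic carbon. Within the data shown here, the measured step concerns a different place on the molecule and says nothing about swapping one aryl ring for another, so no measured step bears on this change. The expected step in this assay is therefore no change at the digits printed from compound 1 to compound 3 (within the scatter), that is, no change beyond the scatter, with wide uncertainty. Compound 3 is estimated at 9000 nM, within a range from 2500 nM to 32000 nM.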

Compound 3, half-maximal inhibitory concentration: 200 nM
Estimate against measurement, compound 3: 45-fold (1.65 log units) above, and the stated range ends above it.
By their numbers in this assay, from the lowest: compound 3; then compound 1; then compound 2.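

The aryl group on this double-bonded chain carbon turns out to be a place where the cell number can move a long way: in this assay the change to 2,3-dichlorophenyl gives a 45-fold lower number from compound 1 to compound 3 (1.65 log units; beyond the scatter) and puts compound 3 lowest of the three. The one earlier step, a 4.6-fold higher number from compound 1 to compound 2 (0.66 log units; beyond the scatter) at a different place on the molecule, was modest and went the other way, so this is the first change shown that lowers the number. Nothing available explains why this swap has so large an effect.

The swap removes the methoxy group and adds both chlorines at once, so the compounds shown cannot tell which of these matters. Going by these compounds, a phenyl ring with a single chlorine, or with an amine or a carboxylic acid, would separate these possibilities, and the same swap on the remaining 2-methoxyphenyl group also remains open.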